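From piperidinyl to diisopropylamino: a step with little precedent

The source may report more compounds than this note shows. Statements on the series, on what has been measured and on what is new or still open speak of the compounds shown alone.

Of the compounds shown here, three have been measured in a functional assay on MDA-MB-435S cells (Homo sapiens) for antiproliferative activity, read by MTT assay, with a stated time of 72 h; on this read-out higher numbers stand for weaker inhibition and lower numbers for stronger inhibition. Compound 3 `O=c1c(Cl)c(CSC(=S)N2CCCCC2)oc2ccccc12` gives 770 nM and stands as the lowest of the two numbers, with compound 1 `COc1ccc2occ(CSC(=S)N(C(C)C)C(C)C)c(=O)c2c1` nearest at 1800 nM. Compound 2 `O=c1cc(CSC(=S)N2CCCCC2)oc2ccccc12` reaches only the limit of the assay, > 25000 nM, as noted in the limit of > 25000 nM in this assay, at which 1 of the 3 values shown sits. Among the compounds with values here, the single step between compounds that differ in one place runs from compound 2 to compound 3: an at least 32-fold lower number from compound 2 to compound 3 (1.51 log units; beyond the scatter).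

Compound 4 `CC(C)N(C(=S)SCc1oc2ccccc2c(=O)c1Cl)C(C)C` has not yet been measured. It keeps the chloro of compound 3 and differs only in diisopropylamino in place of piperidin-1-yl on a thiocarbonyl carbon. Within the data shown here, no measured step touches this change: the step from compound 2 to compound 3 concerns the chloro, which compound 4 retains, and compound 1 differs from compound 2 in two places, so its value beside that limit says nothing clean about the amine on its own. Among the measured compounds shown here, with no step bearing on the change, the expectation for compound 4 in this assay is a number close to that of compound 3, with the estimated step from compound 3 to compound 4 being a 1.2-fold higher number from compound 3 to compound 4 (0.07 log units; within the scatter), not beyond the scatter in either direction. Compound 4 is therefore expected to give about 900 nM, within the range from 300 nM to 3000 nM.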

Compound 4, half-maximal inhibitory concentration: 23600 nM
Estimate against measurement, compound 4: 26-fold (1.42 log units) below; measured number above the stated range.
By their numbers in this assay, from the lowest: compound 3; then compound 1; then compound 4. At a limit, above all of these: compound 2.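

With the chloro held in place, diisopropylamino in place of piperidin-1-yl on a thiocarbonyl carbon gives a 31-fold higher number from compound 3 to compound 4 (1.49 log units; beyond the scatter) in this assay, so the amine is a second place where a single change moves the read-out strongly, after the chloro step of an at least 32-fold lower number from compound 2 to compound 3 (1.51 log units; beyond the scatter). The chloro alone therefore does not secure a low number among these compounds: compound 4 carries it and still gives 23600 nM, and the piperidin-1-yl of compound 3 is part of what its number of 770 nM rests on. Nothing among the data shown gives a reason for the size of this step.

Compound 1 also carries diisopropylamino and gives 1800 nM, but it differs from compound 4 in more than one place, so it cannot show whether the amine step holds on another core. Also open, going by these compounds, is whether the step follows the loss of the ring or the branched chains, which an open-chain diethylamino, a smaller pyrrolidin-1-yl or a morpholin-4-yl on the same thiocarbonyl carbon could begin to separate.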